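This account rests on a few compounds, and the source may have more. Where it says the series, first, only, none or still open, it means among the compounds named here.

In an ADME assay on HFF cells (Homo sapiens) for cytotoxicity, read by resazurin assay, with a stated time of 96 h (a lower number here means that less compound is tolerated, a higher number that more compound is tolerated), compound 1 `CN1CCN(c2ccc3nc(-c4cccc5c4OCCO5)c(-c4ccncc4)n3n2)CC1` gives > 50000 nM, which is a limit of the assay. For the measured compounds named here, compound 2 `CN1CCN(c2ccc3nc(-c4cccc(-c5cccs5)c4)c(-c4ccncc4)n3n2)CC1` gives 6700 nM, the only actual number so far in this short series. Compound 3 `CN1CCN(c2ccc3nc(-c4ccc5ncsc5c4)c(-c4ccncc4)n3n2)CC1` carries 1,3-benzothiazol-6-yl in place of 3-(thiophen-2-yl)phenyl on an aromatic carbon. Going by the values given here, one measured step bears on this change. That step, an at least 7.4-fold lower number from compound 1 to compound 2 (0.87 log units; beyond the scatter), brought in the very group that now leaves, so a partial return to a higher number is expected in this assay. Going by these compounds, its true size remains open, as it rests on (the limit of > 50000 nM in this assay, at which 1 of the 2 values shown sits). Among the compounds with values here, no measured step shows the effect of 1,3-benzothiazol-6-yl itself, so the expectation stays wide. The expected change is a 3.0-fold higher number from compound 2 to compound 3 (0.47 log units; beyond the scatter). For compound 3 the estimated value is 20000 nM, with an expected range of 7000 nM to 50000 nM.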

Compound 3, half-maximal cytotoxic concentration: 17500 nM
Compound 3: middle estimate off by 1.1-fold (0.06 log units), on the high side, within the range that was stated.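

In this assay, 1,3-benzothiazol-6-yl in place of 3-(thiophen-2-yl)phenyl gives a 2.6-fold higher number from compound 2 to compound 3 (0.42 log units; beyond the scatter), so the low number of compound 2 is not shared by every sulfur-bearing group on this aromatic carbon. Against the group of compound 1, 1,3-benzothiazol-6-yl still gives an at least 2.8-fold lower number from compound 1 to compound 3 (0.45 log units; beyond the scatter), which places compound 3 between the other two compounds. The value of compound 1, > 50000 nM, is a limit, so the full size of that step stays open: the limit of > 50000 nM in this assay, at which 1 of the 3 values shown sits.

Sulfur occurs in compound 2 and compound 3 but not in compound 1, and no pair shown isolates its contribution from the rest of each group. Going by these compounds, how 1,3-benzoxazol-6-yl, with oxygen in place of the ring sulfur, or an unsubstituted phenyl would read at this place remains open.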